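The compounds below may be only part of what the source reports. "The series", "measured", "known", "first", "only" and "open" are said of these compounds alone.

Working notes on the series. In an ADME assay on microsomes from liver (Rattus norvegicus) for metabolic stability, read by LC-MS, tested at 1 uM (on this read-out higher numbers stand for a longer-lived compound and lower numbers for a shorter-lived compound), compound 1 `CC(C)(C)n1nc(Cc2cccc(Cl)c2)c2c(N)ncnc21` gives 0.0667 h. Compound 2 `Nc1ncnc2c1c(Oc1cccc(Cl)c1)nn2CC1CCNC(=O)C1` reads > 1 h, which is a limit of the assay and not a number. From the compounds shown here alone, compound 2 therefore stands at the limit of > 1 h in this assay, at which 1 of the 2 values shown sits, so its true half-life remains unknown.

The next compound for measurement is compound 3 `Nc1ncnc2c1c(Oc1cccc(Cl)c1)nn2CC1(C(F)(F)F)CC1`. It differs from compound 2 in one place: 1-(trifluoromethyl)cyclopropyl in place of 2-oxopiperidin-4-yl on a saturated chain carbon bound to an aromatic nitrogen.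

Among the measured compounds shown here, no measured pair differs in one place only, so the series offers no direct measure of such a change in this assay. A shorter half-life is nevertheless expected, though with low confidence. For the measured compounds named here, compound 1, the one measured compound without the 2-oxopiperidin-4-yl group, gives 0.0667 h. That compound also differs from compound 3 elsewhere, so only part of its short half-life is expected to carry over. The expected change is an at least 2.0-fold lower number from compound 2 to compound 3 (0.30 log units; that floor lies within the scatter). For compound 3 the estimated half-life is 0.5 h, with an expected range of 0.15 h to 1 h.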

Compound 3, half-life: 0.183 h
Beside the measured number, compound 3's estimate is 2.7-fold (0.44 log units) above it; measured number inside the range.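

In this assay, among the compounds shown here, the first pair that differs in one place gives a direction for this position, on a saturated chain carbon bound to an aromatic nitrogen: 1-(trifluoromethyl)cyclopropyl in place of 2-oxopiperidin-4-yl brings an at least 5.4-fold lower number from compound 2 to compound 3 (0.73 log units; beyond the scatter). The size of this step is only a floor, since compound 2 reads a limit of the assay and not a number: the limit of > 1 h in this assay, at which 1 of the 3 values shown sits. The two groups share the same count of 7 heavy atoms, whereas the hydrogen-bond donor and hydrogen-bond acceptor of 2-oxopiperidin-4-yl are absent from 1-(trifluoromethyl)cyclopropyl, so the step comes with a change in those counts and not in size by that count.

The compounds shown do not separate the carbonyl, the amide hydrogen and the six-membered ring of 2-oxopiperidin-4-yl from one another, nor do they isolate what the trifluoromethyl contributes in compound 3. From the compounds shown here alone, how a piperidine amine or an unsubstituted cyclopropyl at this place would read in this assay remains open, as does the true half-life of compound 2.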